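A Secondary Pyridinylmethyl Amine Analogue of Compound 1

The source may hold more compounds than are shown below. What is called first, only, known or untested is meant among the compounds shown, and "the series" means these compounds.

Compound 1 `CN(Cc1cccs1)C1CCN(CCCc2c[nH]c3ccc(-n4cnnc4)cc23)CC1` was tested in an assay on CHO cells for displacement of a labelled ligand from 5-hydroxytryptamine receptor 1B (Homo sapiens) (a higher number here means a weaker inhibitor, a lower number a stronger inhibitor), where compound 1 gives 140 nM, the highest of the two numbers measured. Compound 2 `CC(=O)Nc1ccc(CN(C)C2CCN(CCCc3c[nH]c4ccc(-n5cnnc5)cc34)CC2)cc1` gives 100 nM in this assay; the step of a 1.4-fold lower number from compound 1 to compound 2 (0.15 log units; within the scatter) shows that exchanging the aryl group on the saturated chain carbon barely moves the number. Compound 3 `c1cncc(CNC2CCN(CCCc3c[nH]c4ccc(-n5cnnc5)cc34)CC2)c1` differs from compound 1 by ((pyridin-3-yl)methyl)amino in place of methyl((thiophen-2-yl)methyl)amino on a saturated ring carbon. Within the data shown here, only that one measured step bears on the aryl exchange; nothing measured speaks to the loss of the methyl on the amine nitrogen. Compound 3 is therefore expected to show a step of a 1.1-fold lower number from compound 1 to compound 3 (0.03 log units; within the scatter) that stays within the scatter. Compound 3 is estimated at 130 nM, within 40 nM to 450 nM.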

Compound 3, half-maximal inhibitory concentration: 140 nM
Compound 3: the middle estimate sits 1.1-fold (0.03 log units) below what was measured; measured number inside the range.
By their numbers in this assay, from the lowest: compounds 2, 1 and 3 (each within the scatter of the next).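

In this assay, ((pyridin-3-yl)methyl)amino in place of methyl((thiophen-2-yl)methyl)amino on the saturated ring carbon gives no change at the digits printed from compound 1 to compound 3 (within the scatter) and thus shows that this position accepts a change of both the aromatic ring and the amine substitution without a readable shift in the number. Nothing shown accounts for this result. On these data alone, the two changes arrive together in this one step, so their separate contributions stay unknown. Still open, as far as these compounds go, is whether ((thiophen-2-yl)methyl)amino or methyl((pyridin-3-yl)methyl)amino would give a similar number, and whether an unsubstituted amine at this ring carbon would do the same.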